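The source may report more compounds than this note shows. Statements on the series, on what has been measured and on what is new or still open speak of the compounds shown alone.

Compounds measured so far in an ADME assay on Raji cells (Homo sapiens) for cytotoxicity, with a stated time of 72 h; on this read-out lower numbers stand for an effect already at smaller amounts and higher numbers for an effect only at larger amounts of compound:

compound 1, `COc1ccc(NC(=O)Nc2cc(C)nc3ccccc23)cc1`: > 25000 nM, a limit of the assay
compound 2, `Cc1cc(NC(=O)Nc2ccccc2F)c2ccccc2n1`: > 25000 nM, a limit of the assay
compound 3, `Cc1cc(NC(=O)Nc2ccc(F)cc2)c2ccccc2n1`: > 25000 nM, a limit of the assay

None of the three gives a number in this assay; every value is a limit, and (the limit of > 25000 nM in this assay, at which 3 of the 3 values shown sit). Compound 3 therefore stands nowhere in particular on the read-out: only a limit is known for it, and the same holds for the two other compounds. The two steps that lead to compound 3 cannot be read: a step that the two limits leave unreadable from compound 1 to compound 3 and a step that the two limits leave unreadable from compound 2 to compound 3, both hidden by the limits.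

Compound 4, `Cc1cc(NC(=O)Nc2ccc(F)cc2F)c2ccccc2n1`, is not yet measured. It differs from compound 3 by fluoro in place of hydrogen on an aromatic carbon. Going by the values given here, no measured step bears on this change with a readable size, and all values seen so far sit at the limit, so no shift beyond the scatter is expected in either direction. Compound 4 is expected to give about 30000 nM in this assay, within 15000 nM to 100000 nM. This corresponds to an expected step that the limit leaves unreadable from compound 3 to compound 4, most likely again reported only as a limit.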

Compound 4, half-maximal effective concentration: > 25000 nM
Compound 4 was reported as a limit (the forecaster's own chance of this, stated with the estimate: 85%); the middle value is on the limit's open side.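

In this assay compound 4 gives > 25000 nM, a limit of the assay, so its steps from compound 2 and compound 3 cannot be read: the limit of > 25000 nM in this assay, at which 4 of the 4 values shown sit.

The compounds shown leave open whether compounds 1 to 4 differ from one another at all in this assay.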